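Spiro series: paw edema inhibition, furan to methoxyphenyl swap

The source may report more compounds than this note shows. Statements on the series, on what has been measured and on what is new or still open speak of the compounds shown alone.

Measured so far:
- compound 1 `CN1C(=O)[C@@]2(c3ccccc31)N(C)C[C@@H](c1ccco1)[C@@]21Cc2ccccc2C1=O`: 8.2%
- compound 2 `CN1C[C@@H](c2cccs2)[C@@]2(Cc3ccccc3C2=O)[C@@]12C(=O)Nc1ccccc12`: 20%

Among the measured compounds shown here, in a functional assay on the whole organism (strain Wister albino) for inhibition, with Rattus norvegicus as the target, read by paw edema, with stated times of 1 h and 4 h, at a dose of 50 mg/kg by the intraperitoneal route (a lower number here means less inhibition, a higher number more inhibition at the dose given (going by the name of the read-out)), compound 1 gives 8.2%, the lower of the two numbers known. For the measured compounds named here, compound 2 gives 20%, a value that lies beyond the scatter above compound 1; no step between these two is worked out, so the pair only shows that compound 2 inhibits more at this dose.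

Compound 3 `COc1ccc([C@@H]2CN(C)[C@]3(C(=O)N(C)c4ccccc43)[C@]23Cc2ccccc2C3=O)cc1` is not yet measured. Its difference from compound 1 is 4-methoxyphenyl in place of furan-2-yl on a saturated ring carbon. Going by the values given here, no step of this kind is known, so the size of the change in this assay cannot be read from earlier pairs. The expectation is a modest rise, not clearly beyond the scatter, as the estimated step of a number 5.8 percentage points higher from compound 1 to compound 3 (within the scatter) shows. Compound 3 is expected to give 14%, with a range from 3% to 30%.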

Compound 3, a percentage reported as inhibition, in the whole organism at one dose (the size of the read-out at that dose, not a potency): 3.8%
Beside the measured number, compound 3's estimate is 10.2 percentage points above it, and the stated range covers the measured number.
By their numbers in this assay, from the lowest: compounds 3 and 1 (each within the scatter of the next); then compound 2.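

Putting 4-methoxyphenyl in place of furan-2-yl on this saturated ring carbon gives, in this assay, a number 4.4 percentage points lower from compound 1 to compound 3 (within the scatter). Among the compounds shown here, this is the first step read at this position, and it shows that, at the single dose tested, a six-membered aromatic ring of carbon only and a five-membered aromatic ring with 1 hetero atom cannot be told apart here. No measurement on hand offers an explanation for this result.

From the compounds shown here alone, it remains open whether a different kind of group on this carbon, such as an aminomethyl group or a carboxylic acid, would shift the paw edema read-out beyond the scatter. Also open, going by these compounds, is whether the same change would read alike on the core of compound 2.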